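One side group swapped in compound 3

A few compounds are considered here, and "the series" means these few. Any claim that something is new, unique, unknown or untested is made for them only; others in the source may bear on it.

Compound 1 (`CCC(C)n1ncn(-c2ccc(N3CCN(c4ccc(OC[C@@H]5CO[C@@](CBr)(c6ccc(Cl)cc6Cl)O5)cc4)CC3)cc2)c1=O`) carries bromo, compound 2 (`CCC(C)n1ncn(-c2ccc(N3CCN(c4ccc(OC[C@@H]5CO[C@@](CC6CCCC6)(c6ccc(Cl)cc6Cl)O5)cc4)CC3)cc2)c1=O`) carries cyclopentyl and compound 3 (`CCC(C)n1ncn(-c2ccc(N3CCN(c4ccc(OC[C@@H]5CO[C@@](Cn6ccnc6-c6ccccc6)(c6ccc(Cl)cc6Cl)O5)cc4)CC3)cc2)c1=O`) carries 2-phenyl-1H-imidazol-1-yl, each on a saturated chain carbon bound to a saturated ring carbon of a shared core. In a functional assay on HUVEC cells (Homo sapiens), read by scintillation counting and thymidine incorporation, with a stated time of 24 h (a higher number here means a weaker inhibitor, a lower number a stronger inhibitor), compound 1 gives 569 nM and compound 2 gives 512 nM as its value. The step of a 1.1-fold lower number from compound 1 to compound 2 (0.05 log units; within the scatter) lies within the scatter, so these two cannot be told apart. Compound 3 reads 136 nM and is the strongest inhibitor of the three. The steps of a 4.2-fold lower number from compound 1 to compound 3 (0.62 log units; beyond the scatter) and a 3.8-fold lower number from compound 2 to compound 3 (0.58 log units; beyond the scatter) are modest but beyond the scatter.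

Compound 4 (`CCC(C)n1ncn(-c2ccc(N3CCN(c4ccc(OC[C@@H]5CO[C@@](Cn6ncnn6)(c6ccc(Cl)cc6Cl)O5)cc4)CC3)cc2)c1=O`) has 2H-tetrazol-2-yl in place of 2-phenyl-1H-imidazol-1-yl (2H-tetrazol-2-yl in place of 2-phenyl-1H-imidazol-1-yl on a saturated chain carbon bound to a saturated ring carbon) at that same place. For the measured compounds named here, no measured compound carries the entering group, so the guide is rough. Compound 4 gives up the group found only in compound 3, which makes the two modest steps into compound 3 the ones that bear on this change. Read backwards, they suggest a rise of similar or somewhat smaller size. A higher number is therefore expected in this assay, estimated as a 2.4-fold higher number from compound 3 to compound 4 (0.37 log units; beyond the scatter) with wide uncertainty. For compound 4 the estimated value is 320 nM (expected range 110 nM to 900 nM).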

Compound 4, half-maximal inhibitory concentration: 124 nM
Estimate against measurement, compound 4: 2.6-fold (0.41 log units) above; measured number inside the range.
By their numbers in this assay, from the lowest: compounds 4 and 3 (each within the scatter of the next); then compounds 2 and 1 (each within the scatter of the next).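

In this assay the change shows a 1.1-fold lower number from compound 3 to compound 4 (0.04 log units; within the scatter) and so lies within the scatter: 2-phenyl-1H-imidazol-1-yl, with 11 heavy atoms and two rings, and 2H-tetrazol-2-yl, with 5 heavy atoms and one ring, cannot be told apart at this place. The phenyl ring of compound 3 is therefore not required for a low number here, as compound 4 lacks it and still shows a 4.1-fold lower number from compound 2 to compound 4 (0.62 log units; beyond the scatter) and a 4.6-fold lower number from compound 1 to compound 4 (0.66 log units; beyond the scatter) as modest steps beyond the scatter. Among these four compounds, the two nitrogen-containing five-membered aromatic rings read lower than cyclopentyl and bromo, with no compound going against this, but nothing shown here explains that split or the match between compound 3 and compound 4.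

The compounds leave open whether the nitrogen-rich ring itself matters, since a plain 1H-imidazol-1-yl or a simple non-aromatic amine such as morpholine at this place would help separate the ring type from its size. A carboxylic acid or a longer carbon chain on the same saturated chain carbon would also show how widely this place accepts change.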